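The compounds below may be only part of what the source reports. "The series", "measured", "known", "first", "only" and "open" are said of these compounds alone.

Compound 1 `COc1cc(-c2nccn3cc(-c4ccc(Cl)cc4)nc23)cc(OC)c1OC`: 475 nM
Compound 2 `COc1cc(-c2nccn3cc(-c4ccc([N+](=O)[O-])cc4)nc23)cc(OC)c1OC`: > 10000 nM

For the measured compounds named here, in a functional assay on HepG2 cells (Homo sapiens) for inhibition, read by MTT assay, with a stated time of 48 h (on this read-out higher numbers stand for weaker inhibition and lower numbers for stronger inhibition), compound 1 gives 475 nM, the only true number available so far. Compound 2 gives > 10000 nM, which is a limit of this assay and not a number. Compound 1 therefore cannot be ranked within a series of numbers. It can only be set against (the limit of > 10000 nM in this assay, at which 1 of the 2 values shown sits).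

Compound 3 `COc1cc(-c2nccn3cc(-c4ccc(C(F)(F)F)cc4)nc23)cc(OC)c1OC` has not yet been measured. It departs from compound 1 by trifluoromethyl in place of chloro on an aromatic carbon, with trifluoromethyl in place of chloro on an aromatic carbon, para to a large group.

Going by the values given here, one measured step bears on this change, at the same place on the same ring. It is an at least 21-fold higher number from compound 1 to compound 2 (1.32 log units; beyond the scatter), large and beyond the scatter, with nitro in place of chloro. That single step suggests the readout can respond strongly to the group at this place, but nitro is a different group from trifluoromethyl, so only part of its size is carried over.

The estimated step is a 2.5-fold higher number from compound 1 to compound 3 (0.40 log units; beyond the scatter), expected to run towards weaker inhibition. For compound 3 the expected value is 1200 nM, with an estimated range of 300 nM to 6000 nM.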

Compound 3, half-maximal inhibitory concentration: 2630 nM
Compound 3: middle estimate off by 2.2-fold (0.34 log units), on the low side, within the range that was stated.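

In this assay, the change from chloro to trifluoromethyl on an aromatic carbon, para to a large group, can now be sized with a true number at each end: a 5.5-fold higher number from compound 1 to compound 3 (0.74 log units; beyond the scatter). With this, a second group at this place reads weaker than chloro, and of the three groups shown, chloro gives the lowest number, since its steps to both others lie beyond the scatter. The step of an at least 3.8-fold lower number from compound 2 to compound 3 (0.58 log units; beyond the scatter) also shows that the two replacements of chloro are not equal, yet its full size stays unknown, as compound 2 gives only a limit of the assay and not a number: the limit of > 10000 nM in this assay, at which 1 of the 3 values shown sits.

The compounds shown leave open how an amine, a methoxy group or a plain hydrogen would read at this place, and so whether any group here can give a lower number than chloro does in compound 1. They also leave open whether the order of chloro, trifluoromethyl and nitro would hold if another part of the shared core were changed.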